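A Second Chlorine, Placed Twice on the Same Core

This account rests on a few compounds, and the source may have more. Where it says the series, first, only, none or still open, it means among the compounds named here.

Compound 2 `ClCc1ccccc1Cn1cnc2c(Cl)ncnc21` is the starting point. In a functional assay on MCF7 cells (Homo sapiens) for cytotoxicity, read by sulforhodamine B assay, with a stated time of 48 h (a lower number here means a stronger inhibitor of growth, a higher number a weaker inhibitor of growth), compound 2 gives only a limit of the assay rather than a number, > 100000 nM. Compound 1 `ClCc1ccccc1Cn1cnc2c(Cl)nc(Cl)nc21` differs from it by chloro in place of hydrogen on an aromatic carbon. In this assay compound 1 gives 1820 nM. The step of an at least 54-fold lower number from compound 2 to compound 1 (1.73 log units; beyond the scatter) can be stated only as a lower bound because the limit of > 100000 nM in this assay, at which 1 of the 3 values shown sits, is where compound 2 sits.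

Compound 3 `ClCc1cccc(Cn2cnc3ncnc(Cl)c32)c1` has the same atoms as compound 2 joined differently; the difference between the two cores is not broken down here. In this assay compound 3 gives 3980 nM, which leaves it with the highest number among the two compounds that give a number.

Compound 4 `ClCc1cccc(Cn2cnc3nc(Cl)nc(Cl)c32)c1` has not yet been measured. Within the data shown here, it differs from compound 3 by chloro in place of hydrogen on an aromatic carbon, the same change as the one that separates compound 2 from compound 1. In this assay compound 4 is expected to give about 1000 nM, with a likely range from 300 nM to 4000 nM. The expected step of a 4.0-fold lower number from compound 3 to compound 4 (0.60 log units; beyond the scatter) is judged smaller than the earlier one, and this rests on compound 3 already giving 3980 nM, a number that leaves less room for a further drop than compound 2 had before its chlorine was added.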

Compound 4, concentration for total growth inhibition: 4070 nM
For compound 4 the middle estimate is 4.1-fold (0.61 log units) below the measured one; measured number above the stated range.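

In this assay, chloro in place of hydrogen on an aromatic carbon gives a 1.0-fold higher number from compound 3 to compound 4 (0.01 log units; within the scatter), so on this core the added chlorine brings no change that can be told from the scatter. Set beside the earlier result, the two steps clearly differ: the same change on two cores in this assay, an at least 54-fold lower number (1.73 log units; beyond the scatter) from compound 2 to compound 1 and a 1.0-fold higher number (0.01 log units; within the scatter) from compound 3 to compound 4, at least 56-fold (1.74 log units) apart, beyond the scatter of two such steps

This shows that the large drop seen on the core of compound 2 does not carry over to the core of compound 3, so the step from one core cannot be taken as a guide to the other, although two cores give no explanation for the difference and no rule for a third core, and the size of the earlier step remains open at its upper end, as it rests on a limit: the limit of > 100000 nM in this assay, at which 1 of the 4 values shown sits.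

From the compounds shown here alone, it stays open whether an amine or a methoxy group entering at the same place, between two ring nitrogen atoms, would give a large step on both cores, on one or on neither. Also open, going by these compounds, is how the two cores would compare if the chloromethyl group gave way to a hydroxymethyl group or a longer chain.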